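The compounds below may be only part of what the source reports. "The series", "measured", "known", "first", "only" and "open" are said of these compounds alone.

Compound 1 `CC1=CCC[C@H]2[C@](C)(CC3=CC(=O)C=C(NCCC(=O)O)C3=O)[C@@H](C)CC[C@]12C` is the strongest inhibitor of the three measured compounds: in a functional assay on MDA-MB-453 cells (Homo sapiens) for cytotoxicity, read by MTT assay, with a stated time of 72 h (a higher number here means a weaker inhibitor, a lower number a stronger inhibitor), compound 1 gives 3310 nM. Compound 2 `C[C@H](NC1=CC(=O)C=C(C(C)(C)C)C1=O)C(=O)O` gives 112000 nM and compound 3 `CC(C)C[C@H](NC1=CC(=O)C=C(C(C)(C)C)C1=O)C(=O)O` gives 84900 nM, both far weaker. Within the data shown here, the only measured one-place step, a 1.3-fold lower number from compound 2 to compound 3 (0.12 log units; within the scatter), shows that enlarging the side chain of the amino acid bound to the ring makes no difference beyond the scatter. Compound 4 `CSCC[C@H](NC1=CC(=O)C=C(C[C@]2(C)[C@@H](C)CC[C@]3(C)C(C)=CCC[C@@H]23)C1=O)C(=O)O` carries the core of compound 1 with the change (1-carboxy-3-(methylsulfanyl)propyl in place of 2-carboxyethyl on an amine nitrogen). Since the amino acid side chain altered little in compounds 2 and 3, the step is expected to be small: a 1.2-fold higher number from compound 1 to compound 4 (0.08 log units; within the scatter). Compound 4 is therefore estimated at 4000 nM, ranging from 1500 nM to 12000 nM.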

Compound 4, half-maximal inhibitory concentration: 25600 nM
Compound 4: the middle estimate sits 6.4-fold (0.81 log units) below what was measured; the whole stated range lies below it.
By their numbers in this assay, from the lowest: compound 1; then compound 4; then compounds 3 and 2 (each within the scatter of the next).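

On the core of compound 1, the group on this amine nitrogen matters: in this assay, 1-carboxy-3-(methylsulfanyl)propyl in place of 2-carboxyethyl gives a 7.7-fold higher number from compound 1 to compound 4 (0.89 log units; beyond the scatter), a step beyond the scatter. Among these compounds, the only earlier step, a 1.3-fold lower number from compound 2 to compound 3 (0.12 log units; within the scatter), stayed within the scatter, so that pair gave no hint of this sensitivity. Nothing measured here gives a reason for the step.

Still open, from the compounds shown here alone, is whether a 1-carboxyethyl group on the same nitrogen would track compound 1 or compound 4. Also open, going by these compounds, is what a longer chain ending in a carboxylic acid, or one ending in an amine, would do.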